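Cytotoxicity notes: chloro for trifluoromethyl on the sulfonamide aryl

This account rests on a few compounds, and the source may have more. Where it says the series, first, only, none or still open, it means among the compounds named here.

Measured so far:
compound 1 `O=S(=O)(Nc1ccc(-c2nc3ccccc3o2)cc1)c1ccc(Cl)c(C(F)(F)F)c1` — 69000 nM
compound 2 `O=S(=O)(Nc1ccc2oc(-c3ccccc3)nc2c1)c1ccc(Cl)c(C(F)(F)F)c1` — 66000 nM

Both compounds share a sulfonamide bearing a chloro and a trifluoromethyl group on one aromatic ring. In an ADME assay on HEK293 cells (Homo sapiens) for cytotoxicity, read by resazurin assay, with a stated time of 48 h (a higher number here means that more compound is tolerated, a lower number that less compound is tolerated), compound 1 gives 69000 nM and compound 2 gives 66000 nM; the two numbers lie within the scatter of each other, so compound 1 stands level with compound 2 on this read-out and no order between them can be drawn.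

Compound 3 `O=S(=O)(Nc1ccc(-c2nc3ccccc3o2)cc1)c1ccc(Cl)c(Cl)c1` is not yet measured. It differs from compound 1 in one place: chloro in place of trifluoromethyl on an aromatic carbon

Going by the values given here, nothing among the measured compounds reports a step of this kind, so the expectation rests on the closeness of compound 1 and compound 2 alone. No step beyond the scatter is expected from compound 1 to compound 3, that is an estimated 1.0-fold higher number from compound 1 to compound 3 (0.01 log units; within the scatter), in either direction. For compound 3 the estimated half-maximal cytotoxic concentration in this assay is 70000 nM, with a range from 35000 nM to 140000 nM.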

Compound 3, half-maximal cytotoxic concentration: > 100000 nM
Compound 3: only a limit was reported (the forecaster's own chance of this, stated with the estimate: 15%); middle value at least 1.4-fold (0.15 log units) away from the limit.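

Going by these compounds alone, this is the first single-place step: on an aromatic carbon ortho to a chloro group, chloro in place of trifluoromethyl gives an at least 1.4-fold higher number from compound 1 to compound 3 (0.16 log units; that floor lies within the scatter). The position therefore accepts the smaller group with no loss of tolerated concentration in this assay, although the floor of this step does not separate compound 3 from compound 1 beyond the scatter. For compound 3, > 100000 nM is a limit and not a number, so the full size of the step cannot be read because the result rests on that limit: the limit of > 100000 nM in this assay, at which 1 of the 3 values shown sits.

On these data alone, whether the same exchange on compound 2 would give a comparable step remains open. Also open, as far as these compounds go, is how the read-out would respond to an amine or a carboxylic acid at this position.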